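From 4-chlorobenzyl to 3-fluoro-4-methoxybenzyl in compound 3

The source may report more compounds than this note shows. Statements on the series, on what has been measured and on what is new or still open speak of the compounds shown alone.

Measured so far in a functional assay on PC-3 cells (Homo sapiens) for antiproliferative activity, read by MTT assay, with a stated time of 48 h; a lower number here means a stronger inhibitor, a higher number a weaker inhibitor
- compound 1 `COc1cc(N(Cc2ccccc2)C(=O)CSc2nc3ccccc3s2)cc(OC)c1OC`: 54100 nM
- compound 2 `COc1cc(N(Cc2ccc(Cl)cc2)C(=O)CSc2nc3ccccc3s2)cc(OC)c1OC`: > 80000 nM (a limit)

In this assay compound 2 reads > 80000 nM and this is a limit of the assay, not a number. The change to compound 3 `COc1ccc(CN(C(=O)CSc2nc3ccccc3s2)c2cc(OC)c(OC)c(OC)c2)cc1F` is this one (3-fluoro-4-methoxyphenyl in place of 4-chlorophenyl on a saturated chain carbon bound to an amide-type nitrogen) and it puts 3-fluoro-4-methoxyphenyl in place of 4-chlorophenyl on a saturated chain carbon bound to an amide-type nitrogen. Among the compounds with values here, only one measured step touches this group (an at least 1.4-fold higher number from compound 1 to compound 2 (0.16 log units; that floor lies within the scatter)) and it gives a floor, not a size. Within the data shown here, no measured compound carries the entering group, so no step beyond the scatter is expected in this assay and no direction can be told. Among the measured compounds shown here, with compound 1 at 54100 nM as the only number available, the expected step is small (an at least 1.2-fold lower number from compound 2 to compound 3 (0.09 log units; that floor lies within the scatter)). For compound 3 the estimate is 65000 nM (expected range 30000 nM to 110000 nM).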

Compound 3, half-maximal inhibitory concentration: 20100 nM
Compound 3: middle estimate off by 3.2-fold (0.51 log units), on the high side; the measured number lies below the stated range.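

In this assay, within the data shown here, the group on the saturated chain carbon bound to an amide-type nitrogen now shows a change that lowers the number, whereas the only earlier step there gave a floor in the other direction. Putting 3-fluoro-4-methoxyphenyl in place of phenyl gives a 2.7-fold lower number from compound 1 to compound 3 (0.43 log units; beyond the scatter), and putting it in place of 4-chlorophenyl gives an at least 3.9-fold lower number from compound 2 to compound 3 (0.59 log units; beyond the scatter). That second step is only a floor, as compound 2 stands at a limit and not at a number: the limit of > 80000 nM in this assay, at which 1 of the 3 values shown sits.

The compounds shown do not separate the share of the fluorine from that of the methoxy in the entering group. They also leave open how a phenyl ring carrying an amine or a carboxylic acid would read at this place, or a longer chain in place of the benzyl carbon.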